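The source may report more compounds than this note shows. Statements on the series, on what has been measured and on what is new or still open speak of the compounds shown alone.

Among the measured compounds shown here, compound 1 `OCC#CCSc1cnc2ccccc2c1SCC#CCBr` stands lowest of the three numbers measured so far: in a functional assay on CCRF-CEM cells (Homo sapiens) for cytotoxicity, read by sulforhodamine B assay, with a stated time of 72 h (a lower number here means a stronger inhibitor, a higher number a weaker inhibitor), compound 1 gives 0.6 ug/mL. Compound 2 `C[Se]c1c(SCC#CCO)cnc2ccccc12` gives 2.1 ug/mL, a change described by a 3.5-fold higher number from compound 1 to compound 2 (0.54 log units; beyond the scatter), while compound 3 `COc1c(SCC#CCO)cnc2ccccc12` gives 22 ug/mL, with a 37-fold higher number from compound 1 to compound 3 (1.56 log units; beyond the scatter) and, from compound 2, a 10-fold higher number from compound 2 to compound 3 (1.02 log units; beyond the scatter).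

Compound 4 `C#CCSc1c(SCC#CCO)cnc2ccccc12` differs from compound 1 by hydrogen in place of bromomethyl on a triple-bonded carbon. For the measured compounds named here, no measured step touches this place alone; the two steps from compound 1 swapped the whole six-heavy-atom group on the aromatic carbon for a smaller one, and both gave higher numbers, the modest one a 3.5-fold higher number from compound 1 to compound 2 (0.54 log units; beyond the scatter) and the large one a 37-fold higher number from compound 1 to compound 3 (1.56 log units; beyond the scatter). Since every departure from compound 1 so far has raised the number, and the bromomethyl is part of what leaves in those steps, a rise beyond the scatter is expected for compound 4, though smaller than either. Compound 4 is expected to show about a 3.3-fold higher number from compound 1 to compound 4 (0.52 log units; beyond the scatter). Compound 4 is therefore estimated at 2 ug/mL, within 0.6 ug/mL to 7 ug/mL.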

Compound 4, concentration for 50% inhibition: 2.7 ug/mL
Estimate against measurement, compound 4: 1.4-fold (0.13 log units) below; the range from low to high includes it.
By their numbers in this assay, from the lowest: compound 1; then compounds 2 and 4 (each within the scatter of the next); then compound 3.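

Taking only the bromomethyl off the triple-bonded carbon gives a 4.5-fold higher number from compound 1 to compound 4 (0.65 log units; beyond the scatter) in this assay and so isolates this single terminal group, which the earlier swaps of the whole six-heavy-atom group could not do. Even without the bromomethyl, the propargylsulfanyl group on the aromatic carbon stands well apart from methoxy, with an 8.1-fold lower number from compound 3 to compound 4 (0.91 log units; beyond the scatter) on that change, whereas a 1.3-fold higher number from compound 2 to compound 4 (0.11 log units; within the scatter) leaves it indistinguishable from the selenium-bearing group of compound 2. Nothing in the data shown explains either the bromomethyl step or the difference from methoxy.

The compounds shown leave open whether another group on the triple-bonded carbon, such as chloromethyl or a longer carbon chain, would give a number like that of compound 1 or like that of compound 4. They also leave open how an amine on the aromatic carbon would compare with methoxy and propargylsulfanyl.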